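The source may hold more compounds than are shown below. What is called first, only, known or untested is meant among the compounds shown, and "the series" means these compounds.

Compound 1 `Cc1cccc(-c2cc(Cl)cc(Cl)c2/C=C/[C@@H]2C[C@@H](O)CC(=O)O2)c1`, compound 2 `Cc1cc(C)cc(-c2cc(Cl)cc(Cl)c2/C=C/[C@@H]2C[C@@H](O)CC(=O)O2)c1` and compound 3 `COc1cccc(-c2cc(Cl)cc(Cl)c2/C=C/[C@@H]2C[C@@H](O)CC(=O)O2)c1` share one core and differ only in the group on one aromatic carbon. In an assay for inhibition of 3-hydroxy-3-methylglutaryl-coenzyme A reductase (Rattus norvegicus) (on this read-out higher numbers stand for weaker inhibition and lower numbers for stronger inhibition), compound 1 gives 16 nM, compound 2 gives 13 nM and compound 3 gives 50 nM, the highest of the three numbers. The step of a 1.2-fold lower number from compound 1 to compound 2 (0.09 log units; within the scatter) stays within the scatter, whereas a 3.1-fold higher number from compound 1 to compound 3 (0.49 log units; beyond the scatter) and a 3.8-fold higher number from compound 2 to compound 3 (0.59 log units; beyond the scatter) are modest. Compound 4 `O=C1C[C@H](O)C[C@@H](/C=C/c2c(Cl)cc(Cl)cc2CCc2ccccc2)O1` differs from compound 3 by phenethyl in place of 3-methoxyphenyl on an aromatic carbon. For the measured compounds named here, no measured step swaps an aromatic ring for a chain at this carbon, so the only guide is that changes here have so far moved this assay by modest amounts at most. For compound 4 the expected step is a 1.3-fold lower number from compound 3 to compound 4 (0.10 log units; within the scatter), and its estimated value is 40 nM, with a range from 10 nM to 160 nM.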

Compound 4, half-maximal inhibitory concentration: 430 nM
For compound 4 the middle estimate is 11-fold (1.03 log units) below the measured one; measured number above the stated range.
By their numbers in this assay, from the lowest: compounds 2 and 1 (each within the scatter of the next); then compound 3; then compound 4.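

In this assay phenethyl costs more than any swap among the earlier groups at this aromatic carbon, with an 8.6-fold higher number from compound 3 to compound 4 (0.93 log units; beyond the scatter) even though both groups count 8 heavy atoms and one aromatic ring. Against the two methyl-bearing rings the loss is large, with a 27-fold higher number from compound 1 to compound 4 (1.43 log units; beyond the scatter) and a 33-fold higher number from compound 2 to compound 4 (1.52 log units; beyond the scatter) and so, in these four compounds, a phenyl ring carried on a chain does not stand in for the three substituted rings. Nothing measured here gives the reason. As far as these compounds go, it remains open how the number depends on chain length: benzyl, with a shorter chain, or 3-phenylpropyl, with a longer one, would address that.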